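Trimming the aryl ring: what to expect for compound 3

This account rests on a few compounds, and the source may have more. Where it says the series, first, only, none or still open, it means among the compounds named here.

Compound 1 `Cc1cc(C)c(-c2nc(CN3CCC(C(=O)NCCCN4C[C@H](C)C[C@H](C)C4)CC3)c(C)o2)c(C)c1` was run in an ADME assay on microsomes from liver (Rattus norvegicus) for metabolic stability, read by LC-MS, using NADPH, at 37 degrees C; a higher number here means that the compound lasts longer, a lower number that the compound disappears faster. In this assay compound 1 gives > 0.5 h, which is a limit of the assay rather than a measured number. Compound 2 `CCCN(CCC)CCNC(=O)C1CCN(Cc2nc(-c3ccccc3C)oc2C)CC1`, a relative with a different amine end, was also tested; in this assay compound 2 gives > 0.5 h, again a limit rather than a number. Among the measured compounds shown here, both values sit at the limit of > 0.5 h in this assay, at which 2 of the 2 values shown sit, so no order between compound 1 and compound 2 can be read from them, and there is no measured step between two compounds that differ in a single place.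

Compound 3 `Cc1cccc(-c2nc(CN3CCC(C(=O)NCCCN4C[C@H](C)C[C@H](C)C4)CC3)c(C)o2)c1` has not yet been measured. It differs from compound 1 in one place: 3-methylphenyl in place of 2,4,6-trimethylphenyl on an aromatic carbon. For the measured compounds named here, with both known values resting at the limit, the data hold no measured step from which the effect of this change could be judged. The expected step in this assay is a step that the limit leaves unreadable from compound 1 to compound 3, that is, none beyond the scatter. For compound 3 the half-life in this assay is expected to be about 1 h, with a likely range from 0.5 h to 3 h.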

Compound 3, half-life: > 0.5 h
Compound 3: no number, only a limit; the forecaster's own chance of this, stated with the estimate: 70%; the middle value does not contradict the limit.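

In this assay compound 3 gives > 0.5 h, which is a limit and not a number. No step from compound 1 to compound 3 can be read, since all the values shown rest at the same limit: the limit of > 0.5 h in this assay, at which 3 of the 3 values shown sit.

What the compounds shown leave open is the actual half-life of each, and so whether 3-methylphenyl in place of 2,4,6-trimethylphenyl changes it at all.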